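From 2-chlorophenyl to 4-methylphenyl on the shared core

A few compounds are considered here, and "the series" means these few. Any claim that something is new, unique, unknown or untested is made for them only; others in the source may bear on it.

In a functional assay on CCRF-CEM cells (Homo sapiens) for antiproliferative activity (on this read-out lower numbers stand for stronger inhibition and higher numbers for weaker inhibition), compound 3 `COc1cc(C(=O)c2sc(-c3ccccc3Cl)cc2N)cc(OC)c1OC` gives 16 nM, and compound 2 `COc1ccc(-c2cc(N)c(C(=O)c3cc(OC)c(OC)c(OC)c3)s2)cc1OC` gives 20 nM. These two values lie within the scatter of each other, so compound 3 stands level with compound 2. Compound 1 `COc1cc(C(=O)c2sc(-c3ccc(-c4ccccc4)cc3)cc2N)cc(OC)c1OC` reads > 10000 nM, which is a limit of the assay and not a number.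

Compound 4 `COc1cc(C(=O)c2sc(-c3ccc(C)cc3)cc2N)cc(OC)c1OC` carries 4-methylphenyl in place of 2-chlorophenyl, on an aromatic carbon next to the ring sulfur (4-methylphenyl in place of 2-chlorophenyl on an aromatic carbon). Going by the values given here, one measured step bears directly on this change, since it swaps one group for another at the same place. That step, a 1.3-fold lower number from compound 2 to compound 3 (0.10 log units; within the scatter), replaced 3,4-dimethoxyphenyl with 2-chlorophenyl and stayed within the scatter. Compound 1, with its limit of > 10000 nM, also differs at this place, so the upper end of the range is kept wide. On this basis, a 1.6-fold higher number from compound 3 to compound 4 (0.19 log units; within the scatter) is the expected step in this assay, which would be no change beyond the scatter. For compound 4 the estimated value is 25 nM, with an expected range from 6 nM to 150 nM.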

Compound 4, half-maximal inhibitory concentration: 15 nM
For compound 4 the middle estimate is 1.7-fold (0.22 log units) above the measured one; the measured number falls inside the stated range.
By their numbers in this assay, from the lowest: compounds 4, 3 and 2 (each within the scatter of the next). At a limit, above all of these: compound 1.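

In this assay, compound 4 shows that 4-methylphenyl sits level with the two other single-ring groups at this place, as a 1.1-fold lower number from compound 3 to compound 4 (0.03 log units; within the scatter) and a 1.3-fold lower number from compound 2 to compound 4 (0.12 log units; within the scatter) both show. The contrast with compound 1 is sharper, since compound 1 has phenyl where compound 4 has methyl, and this one swap gives an at least 660-fold lower number from compound 1 to compound 4 (2.82 log units; beyond the scatter). The value of compound 1 is a limit and not a number, so the full size of that step stays unknown: the limit of > 10000 nM in this assay, at which 1 of the 4 values shown sits.

The compounds shown leave open how large the group in place of that methyl can grow before the value is lost, for example with a propyl chain. They also leave open whether a ring is needed here at all, which an amine or a carboxylic acid in place of the whole 4-methylphenyl group would test.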